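A few compounds are considered here, and "the series" means these few. Any claim that something is new, unique, unknown or untested is made for them only; others in the source may bear on it.

Of the compounds shown here, three have been tested in a functional assay on the whole organism (strain Swiss) with Mus musculus as the target, in the maximal electroshock model, with a stated time of 0.5 h, at a dose of 100 mg/kg by the intraperitoneal route; a higher number here means a stronger effect of the compound at the dose given, a lower number a weaker effect. Compound 1 `CCC(C(=O)N1CCN(c2ccccc2F)CC1)N1C(=O)CCC1=O` gives 0%. Compound 2 `CCC(C(=O)N1CCN(c2ccccc2)CC1)N1C(=O)CCC1=O` gives 25%, and compound 3 `CC(C(=O)N1CCN(c2ccc(Cl)cc2)CC1)N1C(=O)CCC1=O` gives 25%. Compound 3 therefore stands at the same number as compound 2, its nearest neighbour, and together these two carry the highest numbers shown, while compound 1 lies furthest away from compound 3. Among the compounds with values here, the one step measured between closely related structures, a number 25 percentage points higher from compound 1 to compound 2 (beyond the scatter), came with hydrogen in place of fluoro on an aromatic carbon.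

Compound 4 `CC(C(=O)N1CCN(c2cccc(F)c2)CC1)N1C(=O)CCC1=O` has not yet been measured. It differs from compound 3 by 3-fluorophenyl in place of 4-chlorophenyl on an amine nitrogen in a ring. Within the data shown here, the step from compound 1 to compound 2 bears on this only loosely: there a fluoro gave way to hydrogen and the number rose, whereas here a fluoro enters and a chlorine leaves, a pairing for which no step has been measured. A modest fall is therefore expected, though it may well remain within the scatter. Compound 4 is estimated at 12%, between 0% and 30%, which corresponds to an expected step of a number 13 percentage points lower from compound 3 to compound 4 (beyond the scatter).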

Compound 4, a percentage reported as activity, at one dose (the size of the read-out at that dose, not a potency): 0%
The estimate for compound 4 lay 12 percentage points above the measured number; the measured number falls inside the stated range.
By their numbers in this assay, from the lowest: compounds 1 and 4 (each within the scatter of the next); then compounds 2 and 3 (each within the scatter of the next).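

Replacing 4-chlorophenyl with 3-fluorophenyl on the ring amine nitrogen, with the rest of the molecule unchanged, has a clear effect in this assay: the result is a number 25 percentage points lower from compound 3 to compound 4 (beyond the scatter), a change beyond the usual scatter. The two groups have the same count of heavy atoms and the same six-membered aromatic carbon ring, so the effect at this dose is sensitive to the halogen, to where it sits on that ring, or to both. The change alters those two features together, and this single step does not separate them.

Nothing available gives a reason for this fall. Also open, from the compounds shown here alone, is how the same core would respond to a methoxy group or a nitrile on the phenyl ring.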